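Aryl swap on the triazole nitrogen: compound 3 to compound 4

The source may report more compounds than this note shows. Statements on the series, on what has been measured and on what is new or still open speak of the compounds shown alone.

Measured so far, in a functional assay on A549 cells (Homo sapiens) for antiproliferative activity, read by MTT assay, with a stated time of 48 h; a lower number here means a stronger inhibitor, a higher number a weaker inhibitor:
compound 1 `Cc1ccccc1-n1nncc1CN1C(=O)C2(C(C#N)=C(N)Oc3c(N)cc4nc5ccccc5nc4c32)c2ccccc21` gives 31700 nM
compound 2 `N#CC1=C(N)Oc2c(N)cc3nc4ccccc4nc3c2C12C(=O)N(Cc1cnnn1-c1ccc(F)cc1)c1ccccc12` gives only a limit, > 50000 nM
compound 3 `Cc1cc(C)cc(-n2nncc2CN2C(=O)C3(C(C#N)=C(N)Oc4c(N)cc5nc6ccccc6nc5c43)c3ccccc32)c1` gives 31200 nM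

Compound 3 holds the lowest of the two numbers, with compound 1 sitting within the scatter of it; the remaining value is a limit and not a number. The shared core is kept throughout; only the aryl group on the aromatic nitrogen of the triazole changes.

Compound 4 `CCc1cccc(CC)c1-n1nncc1CN1C(=O)C2(C(C#N)=C(N)Oc3c(N)cc4nc5ccccc5nc4c32)c2ccccc21` continues that variation: 2,6-diethylphenyl in place of 3,5-dimethylphenyl on an aromatic nitrogen.

For the measured compounds named here, three measured steps bear on this. The step of a 1.0-fold lower number from compound 1 to compound 3 (0.01 log units; within the scatter) shows that moving methyl groups around the aryl ring leaves this assay unchanged. As far as these compounds go, the step of an at least 1.5-fold higher number from compound 1 to compound 2 (0.19 log units; that floor lies within the scatter) and the step of an at least 1.6-fold lower number from compound 2 to compound 3 (0.20 log units; that floor lies within the scatter) only reach the floor set by the limit of > 50000 nM in this assay, at which 1 of the 3 values shown sits, so their true size is unknown, and all of them lie within the scatter at that floor. Nothing here separates alkyl-substituted aryl groups from one another beyond the scatter.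

Compound 4 is therefore expected to show no step beyond the scatter, a 1.0-fold higher number from compound 3 to compound 4 (0.01 log units; within the scatter). The estimate for compound 4 in this assay is 32000 nM, with a range from 16000 nM to 60000 nM.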

Compound 4, half-maximal inhibitory concentration: > 50000 nM
Compound 4: only a limit was reported; the forecaster's own chance of this, stated with the estimate: 30%; middle value at least 1.5-fold (0.19 log units) from the limit.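

In this assay compound 4 gives > 50000 nM, which is a limit and not a number, so an alkyl-substituted aryl group on this triazole nitrogen does not always give a readable value. As far as these compounds go, the steps of an at least 1.6-fold higher number from compound 3 to compound 4 (0.20 log units; that floor lies within the scatter) and an at least 1.5-fold higher number from compound 1 to compound 4 (0.19 log units; that floor lies within the scatter) are floors only, so the true size of the change to 2,6-diethylphenyl stays unknown, and the step between compound 2 and compound 4 cannot be read, since both values are limits. The four aryl groups now fall into two sets, with 2-methylphenyl and 3,5-dimethylphenyl giving numbers, while 4-fluorophenyl and 2,6-diethylphenyl reach only the limit: the limit of > 50000 nM in this assay, at which 2 of the 4 values shown sit.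

From the compounds shown here alone, whether the limit for compound 4 follows from the ethyl chains or from their place on the ring stays open, and 2,6-dimethylphenyl and 3,5-diethylphenyl would separate the two. Also open, going by these compounds, is how a 4-aminophenyl or a 4-carboxyphenyl group on the same nitrogen would read in this assay.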